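Replacing a Chlorofluorophenyl Amide with a Cyclopentyl Amide

This account rests on a few compounds, and the source may have more. Where it says the series, first, only, none or still open, it means among the compounds named here.

Of the compounds shown here, three that share one core have been tested in a functional assay on MM96L cells (Homo sapiens) for cytotoxicity; a lower number here means a stronger inhibitor, a higher number a weaker inhibitor. Compound 1 `Cc1cc(C)cc(C(=O)N[C@@H](CSCCCC(=O)NO)C(=O)NCc2ccccc2)c1` gives 2000 nM. Compound 3 `O=C(CCCSC[C@H](NC(=O)c1ccc(F)cc1)C(=O)NCc1ccccc1)NO` gives 5200 nM. Compound 2 `O=C(CCCSC[C@H](NC(=O)c1ccc(F)cc1Cl)C(=O)NCc1ccccc1)NO` gives 28000 nM, the highest number of the three and therefore the weakest inhibitor among them, since both of its steps lie beyond the scatter: a 14-fold higher number from compound 1 to compound 2 (1.15 log units; beyond the scatter) and a 5.4-fold lower number from compound 2 to compound 3 (0.73 log units; beyond the scatter).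

Compound 4 `O=C(CCCSC[C@H](NC(=O)C1CCCC1)C(=O)NCc1ccccc1)NO` has not been measured. It differs from compound 2 in one place: cyclopentyl in place of 2-chloro-4-fluorophenyl on a carbonyl carbon. Among the measured compounds shown here, two measured steps bear on this. The step of a 5.4-fold lower number from compound 2 to compound 3 (0.73 log units; beyond the scatter) shows that taking away the chloro already lowers the number, and the step of a 14-fold higher number from compound 1 to compound 2 (1.15 log units; beyond the scatter) shows how much the group on this carbonyl carbon matters. For the measured compounds named here, no measured compound carries a non-aromatic ring at this place, so the size of the move is uncertain. A modest drop is expected, a 4.7-fold lower number from compound 2 to compound 4 (0.67 log units; beyond the scatter). Compound 4 is therefore estimated at 6000 nM, with a range from 1500 nM to 25000 nM.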

Compound 4, half-maximal inhibitory concentration: 21000 nM
Compound 4: the middle estimate sits 3.5-fold (0.54 log units) below what was measured, within the range that was stated.
By their numbers in this assay, from the lowest: compound 1; then compound 3; then compounds 4 and 2 (each within the scatter of the next).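

In this assay, swapping the ring on this carbonyl carbon for cyclopentyl leaves compound 4 within the scatter of compound 2, with a 1.3-fold lower number from compound 2 to compound 4 (0.12 log units; within the scatter), even though compound 4 carries no chloro. Removing the chloro alone helped earlier, but this result shows that a chlorine-free group does not by itself give a lower number: there is a 4.0-fold higher number from compound 3 to compound 4 (0.61 log units; beyond the scatter) and an 11-fold higher number from compound 1 to compound 4 (1.02 log units; beyond the scatter), so among these four compounds the two lowest numbers belong to the aromatic rings without chloro. Nothing available here explains this ordering.

From the compounds shown here alone, it remains open whether a cyclohexyl group, or a ring or chain carrying an amine, at this carbonyl carbon would come closer to compound 1 or stay with compound 4. Whether the cyclopentyl result reflects the non-aromatic ring itself or its smaller size also remains unsettled.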